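The source may report more compounds than this note shows. Statements on the series, on what has been measured and on what is new or still open speak of the compounds shown alone.

Three compounds with a shared core were tested in an ADME assay on BJ cells (Homo sapiens) for cytotoxicity, read by CellTiter-Glo and resazurin assay, with a stated time of 72 h (on this read-out higher numbers stand for an effect only at larger amounts of compound and lower numbers for an effect already at smaller amounts), and the outcome is the same for each of them: none gave a number, only a limit. Compound 1 `CC(=O)Nc1cccc(-c2ccc(C(=O)N(Cc3cccc(OCCCCCC(=O)O)c3)C(C)C)cc2)c1` reaches the limit > 26000 nM in this assay. Compound 2 `CC(C)N(Cc1cccc(OCCCCCC(=O)O)c1)C(=O)c1ccc(-c2cccc(Oc3ccccc3)c2)cc1` reaches the limit > 18700 nM in this assay. Compound 3 `COc1cc(OC)cc(-c2ccc(C(=O)N(Cc3cccc(OCCCCCC(=O)O)c3)C(C)C)cc2)c1` reaches the limit > 26000 nM in this assay. So compound 3 stands at a limit rather than at a measured value, and the two further values shown are limits as well; two of the three sit at the limit of > 26000 nM in this assay, at which 2 of the 3 values shown sit, and one at the limit of > 18700 nM in this assay, at which 1 of the 3 values shown sits.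

Compound 4 `CC(C)N(Cc1cccc(OCCCCCC(=O)O)c1)C(=O)c1ccc(-c2cccc([N+](=O)[O-])c2)cc1` is built from compound 3 by the change (3-nitrophenyl in place of 3,5-dimethoxyphenyl on an aromatic carbon). Among the compounds with values here, two measured steps touch the same position on the core: a step that the two limits leave unreadable from compound 1 to compound 3 and a step that the two limits leave unreadable from compound 1 to compound 2, and both are unreadable in size, since each runs from one limit to another. No direction and no size can therefore be read for the move to compound 4, and the expectation is that compound 4, like compound 3, will sit at a limit of this assay rather than give a number. On that basis compound 4 is estimated at 30000 nM, within 15000 nM to 60000 nM, which corresponds to an expected step that the limit leaves unreadable from compound 3 to compound 4.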

Compound 4, half-maximal effective concentration: > 26000 nM
Compound 4: a limit, no number (the forecaster's own chance of this, stated with the estimate: 85%); the middle value lies beyond the limit too.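

Compound 4 gives the limit > 26000 nM and no number. Compound 1, compound 2 and compound 3 also stand at limits, so no step among these four compounds can be read. The compounds shown leave open how far each lies past its limit in this assay, and whether any change at this position would give a measured value.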